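Removing the trifluoromethyl group from compound 2

This account rests on a few compounds, and the source may have more. Where it says the series, first, only, none or still open, it means among the compounds named here.

For the measured compounds named here, compound 2 `FC(F)(F)c1cncc(C2=CC3CNCC(C2)C3)c1` is one of three compounds measured in an in vitro assay on SH-EP1 cells for displacement of a labelled ligand from Neuronal acetylcholine receptor; alpha4/beta2 (Homo sapiens); on this read-out lower numbers stand for stronger inhibition and higher numbers for weaker inhibition. Compound 2 gives 0.7 nM, the second highest of the three numbers. Compound 3 `COc1cccc(Oc2cncc(C3=CC4CNCC(C3)C4)c2)c1` gives 0.9 nM, which sits within the scatter of compound 2. Compound 1 `C1=C(c2cccnc2)C[C@H]2CNC[C@@H]1C2` gives 0.2 nM, a step beyond the scatter toward stronger binding. Going by the values given here, no measured pair differs in a single place, so no computed step exists.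

Compound 4 `C1=C(c2cccnc2)CC2CNCC1C2` is not yet measured. It differs from compound 2 as follows: hydrogen in place of trifluoromethyl on an aromatic carbon. Compound 1 already carries hydrogen at that place on a stereodefined core and gives 0.2 nM, so the unsubstituted pattern is compatible with tight binding here.

The expected step from compound 2 to compound 4 is a 2.3-fold lower number from compound 2 to compound 4 (0.37 log units; beyond the scatter), a modest move toward a lower number, near the edge of the scatter. Compound 4 is therefore estimated at 0.3 nM, with a range from 0.12 nM to 0.8 nM in this assay.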

Compound 4, inhibition constant: 0.2 nM
Estimate against measurement, compound 4: 1.5-fold (0.18 log units) above, within the range that was stated.
By their numbers in this assay, from the lowest: compounds 1 and 4 (each within the scatter of the next); then compounds 2 and 3 (each within the scatter of the next).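

Hydrogen in place of trifluoromethyl gives the first single-place comparison at this aromatic carbon, two atoms from the ring nitrogen, in this assay: a 3.5-fold lower number from compound 2 to compound 4 (0.54 log units; beyond the scatter). The trifluoromethyl group is therefore tolerated at this position with tight binding retained, though the unsubstituted compound gives the lower number. The pair of compound 1 and compound 4 shows no change at the digits printed from compound 1 to compound 4 (within the scatter), yet whether the two hold the same stereoisomer composition cannot be told, because of one point of drawing: the fact that one of compounds 1 and 4 is drawn with a defined configuration and the other without, at the place where they differ

From the compounds shown here alone, whether this step is particular to trifluoromethyl stays open, since a single replacement cannot separate it from what a fluorine, a nitrile, an amine or a carboxylic acid would do at this carbon. Going by these compounds, how a longer chain at this position would read also remains open.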